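Two Methyls in Place of an Ethoxy on a Urea

A few compounds are considered here, and "the series" means these few. Any claim that something is new, unique, unknown or untested is made for them only; others in the source may bear on it.

Measured so far in a functional assay on T-24 cells (Homo sapiens) for antiproliferative activity, read by MTT assay, with a stated time of 48 h; a lower number here means a stronger inhibitor, a higher number a weaker inhibitor:
compound 1 `CCOc1ccc(NC(=O)Nc2cccc(CNc3nccnc3Cl)c2)cc1`: 9080 nM
compound 2 `CCc1ccc(NC(=O)Nc2cccc(CNc3nccnc3Cl)c2)c(CC)c1`: 6390 nM

Compound 1 stands highest of the two numbers, meaning it is the weaker inhibitor on paper, but its gap to compound 2 lies within the usual scatter of repeated measurements, so the two cannot be ranked against each other. Within the data shown here, no step between measured compounds is available to set a scale.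

Compound 3 `Cc1ccc(NC(=O)Nc2cccc(CNc3nccnc3Cl)c2)c(C)c1` differs from compound 1 in one place: 2,4-dimethylphenyl in place of 4-ethoxyphenyl on an amide-type nitrogen. The shared core of compound 1 is kept unchanged.

Among the measured compounds shown here, with only two measured compounds, and those two indistinguishable, no clear direction can be drawn. The expected step of a 1.3-fold lower number from compound 1 to compound 3 (0.11 log units; within the scatter) in this assay is small, at most a modest move toward a lower number, because compound 2 gives 6390 nM. Compound 3 is therefore expected to give about 7000 nM, within a range from 3000 nM to 16000 nM.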

Compound 3, half-maximal inhibitory concentration: 9230 nM
Estimate against measurement, compound 3: 1.3-fold (0.12 log units) below, within the range that was stated.
By their numbers in this assay, from the lowest: compounds 2, 1 and 3 (each within the scatter of the next).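

In this assay, swapping 4-ethoxyphenyl for 2,4-dimethylphenyl on the amide-type nitrogen gives a 1.0-fold higher number from compound 1 to compound 3 (0.01 log units; within the scatter), so this first direct comparison at this position shows no readable change. The group that leaves carries an oxygen and a hydrogen-bond acceptor, and the group that enters carries neither, yet this exchange does not separate the two compounds in this read-out. Nothing available here explains why the two numbers stay together.

From the compounds shown here alone, it remains open whether any group at this position can move the number beyond the scatter, for example a phenyl ring bearing an amine or a carboxylic acid, or a longer chain in place of the ethoxy. Going by these compounds, it is also open whether the same exchange would stay as silent on a changed core or in other cells.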